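Ester series on the shared core: tolyl ester

The source may hold more compounds than are shown below. What is called first, only, known or untested is meant among the compounds shown, and "the series" means these compounds.

Measured so far in an assay on isolated protein for antagonist activity at Bile acid receptor (Homo sapiens), read by HTRF, with a stated time of 30 min; a higher number here means a weaker inhibitor, a lower number a stronger inhibitor:
Compound 1 `CC(C)(C)c1cc(OC(=O)c2ccco2)ccc1O` gives > 100000 nM, a limit of the assay.
Compound 2 `CC(C)(C)c1cc(OC(=O)c2ccccc2)ccc1O` gives > 100000 nM, a limit of the assay.

Compound 2 stands at the limit of this assay, with no number of its own; both values shown sit at that limit (the limit of > 100000 nM in this assay, at which 2 of the 2 values shown sit). Within the data shown here, the one step recorded, a step that the two limits leave unreadable from compound 1 to compound 2, is unreadable between two limits. Compound 3 `Cc1ccccc1C(=O)Oc1ccc(O)c(C(C)(C)C)c1` differs from compound 2 by methyl in place of hydrogen on an aromatic carbon. Among the measured compounds shown here, no measured step bears on this change, so no direction can be read. Compound 3 is expected to remain near the limit, estimated at 150000 nM (range 50000 nM to 500000 nM), the expected step being a step that the limit leaves unreadable from compound 2 to compound 3.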

Compound 3, half-maximal inhibitory concentration: > 100000 nM
Compound 3: a limit, no number; the forecaster's own chance of this, stated with the estimate: 85%; the middle value is on the limit's open side.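

Among these compounds, no step among compound 1, compound 2 and compound 3 can be read, because each result is only a limit: the limit of > 100000 nM in this assay, at which 3 of the 3 values shown sit. On these data alone, whether any ester on the shared core gives a measurable inhibitory value remains open.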